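The compounds below may be only part of what the source reports. "The series", "measured", "known", "first", "only" and "open" are said of these compounds alone.

Working notes on the series

Of the compounds shown here, three on the shared core have been measured in a functional assay for antagonist activity at corticotropin-releasing factor receptor 1 (Rattus norvegicus); on this read-out higher numbers stand for weaker inhibition and lower numbers for stronger inhibition. Compound 1 `CCC(C1CC1)n1c(=O)c(C)nc2c(-c3cc(C)c(C)cc3C)ccnc21` gives 5.2 nM. Compound 2 `CCC(C1CC1)n1c(=O)c(C)nc2c(-c3ccc(C)cc3C)ccnc21` gives 8.8 nM. Compound 3 `CC[C@H](C1CC1)n1c(=O)c(C)nc2c(-c3cc(C)c(OC)nc3C)ccnc21` gives 15 nM.

Compound 1 and compound 2 differ in one place, (hydrogen in place of methyl on an aromatic carbon), which read one bond further out is 2,4,5-trimethylphenyl to 2,4-dimethylphenyl. The step is a 1.7-fold higher number from compound 1 to compound 2 (0.23 log units; within the scatter).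

Compound 3 stands highest of the three numbers. Against compound 2 it is within the scatter; against compound 1 the gap is beyond the scatter. How the core of compound 3 differs from the core of compound 1 is not broken down here.

Compound 4 `CC[C@H](C1CC1)n1c(=O)c(C)nc2c(-c3ccc(OC)nc3C)ccnc21` is not yet measured. It differs from compound 3 by hydrogen in place of methyl on an aromatic carbon. Among the measured compounds shown here, this is the same kind of change as the one from compound 1 to compound 2, but not the same: in the earlier pair the ring is of carbon only and the leaving methyl sits ortho to a methyl group, whereas here the six-membered aromatic ring holds one nitrogen and the leaving methyl sits ortho to a methoxy group, two atoms from the ring nitrogen.

With one prior example only, the expectation is a step of about the size seen before, because the earlier removal of an aromatic methyl gave a 1.7-fold higher number from compound 1 to compound 2 (0.23 log units; within the scatter). The step from compound 3 to compound 4 is therefore estimated at a 1.7-fold higher number from compound 3 to compound 4 (0.22 log units; within the scatter) in this assay. Compound 4 is expected to give 25 nM, with a range from 10 nM to 60 nM.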

Compound 4, half-maximal inhibitory concentration: 76 nM
Beside the measured number, compound 4's estimate is 3.0-fold (0.48 log units) below it; measured number above the stated range.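

In this assay, hydrogen in place of methyl on the six-membered aromatic ring with 1 nitrogen gives a 5.1-fold higher number from compound 3 to compound 4 (0.70 log units; beyond the scatter). The change therefore does not carry over at one size from the core of compound 1 to the core of compound 3, and a step read on one of these cores cannot simply be transferred to the other: the same change on two cores in this assay, a 1.7-fold higher number (0.23 log units; within the scatter) from compound 1 to compound 2 and a 5.1-fold higher number (0.70 log units; beyond the scatter) from compound 3 to compound 4, 3.0-fold (0.48 log units) apart, beyond the scatter of two such steps What this does not show is which feature sets the two steps apart: the pairs differ in the ring that carries the methyl and in the groups around it, and also elsewhere in the structure, so two pairs cannot separate these differences or give a rule for further cores.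

Going by these compounds, it remains open whether the larger step on the core of compound 3 is specific to methyl, which a chlorine atom or an ethyl group in the same place on that ring would test against the values of compound 3 and compound 4. On these data alone, it also remains open whether the size of the step depends on the methoxy group, which could be examined by repeating the same methyl-to-hydrogen change with an amine or an ethoxy group in its place.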